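Cyclohexyl to Thiophen-3-yl: Expected Effect on Cell Tolerance

The compounds below may be only part of what the source reports. "The series", "measured", "known", "first", "only" and "open" are said of these compounds alone.

Three compounds have been tested in an ADME assay on MDCK cells (Canis lupus familiaris) for cytotoxicity, read by microscopy, with a stated time of 48 h; a higher number here means that more compound is tolerated, a lower number that less compound is tolerated:

Compound 1, `C[C@H]1[C@H](NCc2sccc2C2CCCCC2)C[C@H]2C[C@@H]1C2(C)C`: 1560 nM
Compound 2, `C[C@H]1[C@H](NCc2ccc(Cl)s2)C[C@H]2C[C@@H]1C2(C)C`: 25000 nM
Compound 3, `C[C@H]1[C@H](NCc2cc(-c3ccccc3)cs2)C[C@H]2C[C@@H]1C2(C)C`: 5000 nM

Among these three, compound 1 has the lowest number, meaning the cells tolerate the least of it. The nearest neighbour is compound 3, whose number lies above that of compound 1 by more than the usual scatter; compound 2 stands furthest away, its number higher still and also well beyond the scatter. All three share the same core, and differ only in what is attached to the five-membered aromatic ring.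

Compound 4, `C[C@H]1[C@H](NCc2sccc2-c2ccsc2)C[C@H]2C[C@@H]1C2(C)C`, is not yet measured. It differs from compound 1 in one place: thiophen-3-yl in place of cyclohexyl on an aromatic carbon. The cyclohexyl leaves and a thiophen-3-yl enters, so a non-aromatic ring gives way to a second aromatic ring.

For the measured compounds named here, no measured pair shows this exact change, so the expected size of the step rests on the three numbers alone. A modest rise in tolerated concentration is expected, because compound 3, which also carries an aromatic ring on the core, gives 5000 nM in this assay. The expected step is a 1.9-fold higher number from compound 1 to compound 4 (0.28 log units; within the scatter). For compound 4 the estimate in this assay is 3000 nM, with a range from 1000 nM to 10000 nM.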

Compound 4, minimum cytotoxic concentration: 12500 nM
Compound 4: the middle estimate sits 4.2-fold (0.62 log units) below what was measured; the measured number lies above the stated range.
By their numbers in this assay, from the lowest: compound 1; then compound 3; then compounds 4 and 2 (each within the scatter of the next).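

In this assay, thiophen-3-yl in place of cyclohexyl gives an 8.0-fold higher number from compound 1 to compound 4 (0.90 log units; beyond the scatter), which is beyond the usual scatter of repeated measurements. For the compounds shown here, the earlier compounds offered no pair differing in one place only, so this is the first direct sign that the group on this aromatic carbon, by itself, can change how much compound the cells tolerate. The change replaces a non-aromatic ring of carbon only with a five-membered aromatic ring containing sulfur, but no measurement here explains the rise in tolerated concentration.

This single pair cannot separate the possible contributions of ring aromaticity, the sulfur atom and ring size, since all three change together. A cyclopentyl group at this place would keep a non-aromatic carbon ring with the same number of ring atoms as thiophen-3-yl, while a pyridin-3-yl group would bring an aromatic ring with nitrogen instead of sulfur, so either could help show which feature tracks with the number.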